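Trimming the Chain and Adding a Nitrile

The source may report more compounds than this note shows. Statements on the series, on what has been measured and on what is new or still open speak of the compounds shown alone.

Compound 1, `COc1cccc(Cc2cnc(CCc3ccc(-c4ccccc4C(=O)O)cc3)[nH]2)c1`, in an in vitro functional assay on cells for agonist activity at Bombesin receptor subtype-3 (Mus musculus), read by luminescence and calcium flux; on this read-out higher numbers stand for an effect only at larger amounts of compound and lower numbers for an effect already at smaller amounts: 79 nM
Compound 2, `O=C(O)c1ccccc1-c1ccc(CCc2ncc(Cc3ccccc3Cl)[nH]2)cc1`, in this assay: 22 nM
Compound 3, `O=C(O)c1ccccc1-c1ccc(CCc2ncc(CCc3ccccc3)[nH]2)cc1`, in this assay: 174 nM

All three share one core and differ only in the aromatic piece attached to its saturated chain carbon. Compound 3, carrying a benzyl group there, shows the highest number of the three, and both steps toward it are beyond the scatter: a 2.2-fold higher number from compound 1 to compound 3 (0.34 log units; beyond the scatter) and a 7.9-fold higher number from compound 2 to compound 3 (0.90 log units; beyond the scatter).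

Compound 4, `N#Cc1cccc(Cc2cnc(CCc3ccc(-c4ccccc4C(=O)O)cc3)[nH]2)c1`, has not yet been measured. It differs from compound 3 by 3-cyanophenyl in place of benzyl on a saturated chain carbon bound to an aromatic carbon.

Going by the values given here, two measured steps bear on this. Each replaces a directly bound substituted phenyl with benzyl and each raises the number: a 2.2-fold higher number from compound 1 to compound 3 (0.34 log units; beyond the scatter) and a 7.9-fold higher number from compound 2 to compound 3 (0.90 log units; beyond the scatter). Compound 4 reverses that kind of change, so a lower number is expected in this assay. Compound 1 carries a 3-methoxyphenyl, the nearest analogue in shape to 3-cyanophenyl, so the expected step is sized closer to that one than to the larger one seen with compound 2.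

Compound 4 is therefore estimated to reach 60 nM, with a range from 25 nM to 160 nM, which means an expected step of a 2.9-fold lower number from compound 3 to compound 4 (0.46 log units; beyond the scatter).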

Compound 4, half-maximal effective concentration: 20 nM
Compound 4: the middle estimate sits 3.0-fold (0.48 log units) above what was measured; measured number outside the range, below it.
By their numbers in this assay, from the lowest: compounds 4 and 2 (each within the scatter of the next); then compound 1; then compound 3.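

Going by these compounds alone, the nitrile gives the cleanest comparison so far, since only one group on the ring changes: in this assay, cyano in place of methoxy gives a 4.0-fold lower number from compound 1 to compound 4 (0.60 log units; beyond the scatter), so what the ring carries matters as well as the length of the link to it. Read against the phenethyl group, the 3-cyanobenzyl arrangement gives an 8.7-fold lower number from compound 3 to compound 4 (0.94 log units; beyond the scatter), which shows that a low number at this position is not tied to the chlorine of compound 2 and can also be reached with a different group at a different place on the ring. The comparison of the two best-performing groups gives a 1.1-fold lower number from compound 2 to compound 4 (0.04 log units; within the scatter), so in this assay 3-cyanophenyl and 2-chlorophenyl cannot be told apart and neither can be ranked over the other.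

Nothing in the data gives a reason for these steps. On these data alone, it remains open whether an amide or an amine in place of the nitrile on this ring, or a trifluoromethyl group, would give a number as low as these two, and whether the nitrile would hold its effect on the longer phenethyl chain.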